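Swapping the aryl group of compound 2

A few compounds are considered here, and "the series" means these few. Any claim that something is new, unique, unknown or untested is made for them only; others in the source may bear on it.

Measured in a functional assay on CCRF-CEM cells (Homo sapiens) for inhibition, read by MTT assay, with a stated time of 72 h (on this read-out lower numbers stand for stronger inhibition and higher numbers for weaker inhibition), so far:
- compound 1 `COc1cc(NC(C)CCCNC(=O)Nc2ccc(F)cc2)c2ncccc2c1` gives 26000 nM
- compound 2 `COc1cc(NC(C)CCCNC(=O)Nc2cccc(C(F)(F)F)c2)c2ncccc2c1` gives 19000 nM

Going by the values given here, compound 2 (19000 nM) lies within the usual scatter of compound 1 (26000 nM), the only other compound measured. The next compound is compound 3 `COc1cc(NC(C)CCCNC(=O)Nc2ccc(Cl)cc2)c2ncccc2c1`, which carries 4-chlorophenyl in place of 3-(trifluoromethyl)phenyl on an amide-type nitrogen. The shared core stays the same.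

Among the compounds with values here, one measured step bears on this change, a 1.4-fold lower number from compound 1 to compound 2 (0.14 log units; within the scatter) when 3-(trifluoromethyl)phenyl stands in place of 4-fluorophenyl at that same nitrogen. Within the data shown here, a single step is thin evidence, and no compound with 4-chlorophenyl has been measured yet. Among the measured compounds shown here, still, the only exchange seen at this place stayed within the scatter, so no step beyond the scatter, in either direction, is expected in this assay. The expected step is small (a 1.1-fold higher number from compound 2 to compound 3 (0.04 log units; within the scatter)). The estimated value for compound 3 is 21000 nM (expected range 10000 nM to 42000 nM).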

Compound 3, half-maximal inhibitory concentration: 24000 nM
Estimate against measurement, compound 3: 1.1-fold (0.06 log units) below; the measured number falls inside the stated range.
By their numbers in this assay, from the lowest: compounds 2, 3 and 1 (each within the scatter of the next).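

In this assay, a third aryl group on the amide-type nitrogen gives a 1.3-fold higher number from compound 2 to compound 3 (0.10 log units; within the scatter), so replacing 3-(trifluoromethyl)phenyl, with 10 heavy atoms, by 4-chlorophenyl, with 7, does not separate the two compounds. The exchange of chloro for fluoro on an aromatic carbon gives a 1.1-fold lower number from compound 1 to compound 3 (0.03 log units; within the scatter), which is also too small to distinguish from repeat-to-repeat variation, so all three aryl groups shown here give matching results, and no compound among the three goes against this. No measured information is available to explain why these exchanges leave the number within the scatter.

These three compounds differ only in a substituted phenyl group, so they leave open whether a quite different group on this nitrogen, such as a simple cyclohexyl ring or a phenyl ring carrying a carboxylic acid or an amine, would produce a step beyond the scatter. They also leave open whether a change elsewhere, such as a longer chain linking the shared core to the carbonyl, would move the number more than these aryl exchanges do.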